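Dimethylamino for Methoxy on the Amide Aryl Ring

This account rests on a few compounds, and the source may have more. Where it says the series, first, only, none or still open, it means among the compounds named here.

Compound 2 `COc1ccc(C(=O)NC(CCN(C)C)c2ccc(Cl)cc2)cc1` gives the lowest of the three numbers in an assay on NIH3T3 cells with Urotensin-2 receptor (Homo sapiens) as the target (a lower number here means that less compound is needed, a higher number that more compound is needed for the effect), at 1350 nM; compound 3 `Cc1c(Cl)cccc1C(=O)NC(CCN(C)C)c1ccc(Cl)cc1` stands within the scatter of it at 1740 nM, and compound 1 `Cc1ccccc1C(=O)NC(CCN(C)C)c1ccc(Cl)cc1` is the furthest at 3550 nM. Compound 4 `CN(C)CCC(NC(=O)c1ccc(N(C)C)cc1)c1ccc(Cl)cc1` differs from compound 2 by dimethylamino in place of methoxy on an aromatic carbon. Going by the values given here, no measured step alters this group alone. The nearest comparisons are a 2.6-fold lower number from compound 1 to compound 2 (0.42 log units; beyond the scatter), which concerns the same ring, and a 1.3-fold higher number from compound 2 to compound 3 (0.11 log units; within the scatter). Both are modest, so the step in this assay is expected to be modest at most, with its direction uncertain. Compound 4 is therefore expected near 1100 nM, between 400 nM and 3000 nM, a change of a 1.2-fold lower number from compound 2 to compound 4 (0.09 log units; within the scatter) that should remain within the scatter.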

Compound 4, half-maximal effective concentration: 1350 nM
Beside the measured number, compound 4's estimate is 1.2-fold (0.09 log units) below it; the range from low to high includes it.
By their numbers in this assay, from the lowest: compounds 2, 4 and 3 (each within the scatter of the next); then compound 1.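

In this assay, dimethylamino in place of methoxy, on an aromatic carbon para to a large group, gives no change at the digits printed from compound 2 to compound 4 (within the scatter). Going by these compounds alone, this is the first step that alters this group alone, and it shows that the position takes dimethylamino, with its three heavy atoms, and methoxy, with its two, at the same printed number. Nothing at hand explains why the two groups read alike. The compounds shown leave open how a primary amine, a hydroxyl or a carboxylic acid would read at this position.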